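Extending the methoxy group of compound 2 to benzyloxy

The source may hold more compounds than are shown below. What is called first, only, known or untested is meant among the compounds shown, and "the series" means these compounds.

Of the compounds shown here, two sharing one core have been measured in an ADME assay on HepG2 cells (Homo sapiens) for cytotoxicity, read by MTT assay, with a stated time of 7 days; a lower number here means a stronger inhibitor, a higher number a weaker inhibitor. Compound 1, `CCCc1ccc(C2CC(c3ccc(O)cc3)=NN2C(=O)c2cccnc2)cc1`, gives 41600 nM. Compound 2, `COc1ccc(C2CC(c3ccc(O)cc3)=NN2C(=O)c2cccnc2)cc1`, gives 42400 nM. Between them lies a single change, a 1.0-fold higher number from compound 1 to compound 2 (0.01 log units; within the scatter), so compound 2 stands with the highest of the two numbers but within the scatter of compound 1. Compound 3, `O=C(c1cccnc1)N1N=C(c2ccc(O)cc2)CC1c1ccc(OCc2ccccc2)cc1`, carries a further change in the same region: phenyl in place of hydrogen on a saturated chain carbon bound to an oxygen on an aromatic ring. Within the data shown here, the only measured step concerns the group at that position and was flat, yet it swapped propyl for methoxy rather than adding a phenyl, so it bears on the new step only loosely. With no step beyond the scatter to build on, the expected change from compound 2 to compound 3 is a 1.3-fold lower number from compound 2 to compound 3 (0.12 log units; within the scatter), a small shift at most. Compound 3 is therefore estimated at 32000 nM in this assay, within 12000 nM to 80000 nM.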

Compound 3, half-maximal inhibitory concentration: 11400 nM
The estimate for compound 3 lay 2.8-fold (0.45 log units) above the measured number; the whole stated range lies above it.
By their numbers in this assay, from the lowest: compound 3; then compounds 1 and 2 (each within the scatter of the next).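

In this assay, among these compounds, this position proves able to move the number: the swap of propyl for methoxy stayed within the scatter, whereas extending methoxy to benzyloxy gives a 3.7-fold lower number from compound 2 to compound 3 (0.57 log units; beyond the scatter) and is the first step here to pass it. Replacing propyl with benzyloxy gives much the same result, a 3.6-fold lower number from compound 1 to compound 3 (0.56 log units; beyond the scatter), so the two routes to compound 3 agree, and the shift is modest in size. The data at hand offer no explanation for this shift.

As far as these compounds go, with a single phenyl-bearing compound, it remains open whether the ring itself matters or whether a longer chain such as butoxy would do the same. Also unresolved is how a chlorine or an amine on the added phenyl ring would change the number.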